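Swapping a Tetrazole for an Isopropyl-Pyrazole

The source may report more compounds than this note shows. Statements on the series, on what has been measured and on what is new or still open speak of the compounds shown alone.

Compound 2 `CC(C)Oc1cc(-c2cncc(-c3nn[nH]n3)c2)ccc1C(N)=O` shares its core with compound 1 `CC(C)Oc1cc(-c2cncc(-c3c[nH]nc3C3CC3)c2)ccc1C(N)=O`; the two differ only in the five-membered ring attached on an aromatic carbon of the six-membered ring with one nitrogen. In an assay on cells for inhibition of MAP kinase-interacting serine/threonine-protein kinase 1 (Homo sapiens), read by mobility shift assay, with stated times of 10 min and 60 min, in the presence of a further agent that is not named here (on this read-out lower numbers stand for stronger inhibition and higher numbers for weaker inhibition), compound 2 gives 310 nM, the highest number of the two measured here, while compound 1 gives 130 nM. Within the data shown here, the single measured step, a 2.4-fold higher number from compound 1 to compound 2 (0.38 log units; beyond the scatter), was a modest change beyond the scatter.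

Compound 3 `CC(C)Oc1cc(-c2cncc(-c3cnn(C(C)C)c3)c2)ccc1C(N)=O` has not yet been measured in this assay. Its change from compound 2 is 1-isopropyl-1H-pyrazol-4-yl in place of 2H-tetrazol-5-yl on an aromatic carbon. As far as these compounds go, because the move in the other direction, a 2.4-fold higher number from compound 1 to compound 2 (0.38 log units; beyond the scatter), put a pyrazole-bearing compound at the lower number, the return to a pyrazole in compound 3 is expected to lower the number again, by a step of about the same modest size, though the new isopropyl on the pyrazole nitrogen is untested in this set. For compound 3 the expected value in this assay is 150 nM, with a range from 60 nM to 400 nM, meaning an expected step of a 2.1-fold lower number from compound 2 to compound 3 (0.32 log units; beyond the scatter).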

Compound 3, half-maximal inhibitory concentration: 85 nM
Estimate against measurement, compound 3: 1.8-fold (0.25 log units) above; the range from low to high includes it.
By their numbers in this assay, from the lowest: compounds 3 and 1 (each within the scatter of the next); then compound 2.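

Placing 1-isopropyl-1H-pyrazol-4-yl on this aromatic carbon in place of 2H-tetrazol-5-yl gives, in this assay, a 3.6-fold lower number from compound 2 to compound 3 (0.56 log units; beyond the scatter) and this is a larger step than the one seen earlier, so both pyrazole-bearing compounds now sit at lower numbers than the tetrazole compound 2, with no compound shown going against that. Set against the 3-cyclopropyl-1H-pyrazol-4-yl group, the isopropyl pyrazole gives a 1.5-fold lower number from compound 1 to compound 3 (0.18 log units; within the scatter) and the two cannot be told apart, which shows that a pyrazole with its carbon group on the ring nitrogen, counted with 0 hydrogen-bond donors, does as well here as the pyrazole of compound 1. Nothing measured here explains why the tetrazole and the pyrazoles differ at this position.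

The compounds shown leave open whether the gain comes from the pyrazole ring itself or from its carbon group, a question that a plain 1H-pyrazol-4-yl with no carbon group would help to settle. They also leave open how much room this position offers, for instance for a longer chain on the pyrazole nitrogen or one ending in an amine.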